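A few compounds are considered here, and "the series" means these few. Any claim that something is new, unique, unknown or untested is made for them only; others in the source may bear on it.

Compound 1 `Cc1cc(-c2nc3c(F)cccc3s2)ccc1N`: no result reported
Compound 2 `Nc1ccc(-c2nc3cc(F)ccc3s2)cc1I`: 70 nM
Compound 3 `Nc1ccc(-c2nc3ccccc3s2)cc1F`: < 10 nM, a limit of the assay

In a functional assay on cells (Cancer cell lines, Homo sapiens) for inhibition (a lower number here means a stronger inhibitor of growth, a higher number a weaker inhibitor of growth), the entry for compound 1 reads no result reported and so the step starts without a number of its own. The nearby evidence is thin. For the measured compounds named here, compound 2 gives 70 nM, the only plain number in the set. Compound 3 gives < 10 nM, which is a limit of the assay and not a number.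

The step leads from compound 1 to compound 4 `Cc1cc(-c2nc3ccccc3s2)ccc1N`. The structural change is small: hydrogen in place of fluoro on an aromatic carbon. In words, hydrogen takes the place of fluoro on an aromatic carbon, and the rest of the structure stays the same.

Going by the values given here, no measured pair of compounds shows this swap directly, so its size in this assay cannot be read from the data. The expectation is therefore a change no larger than the usual scatter, with no direction favoured. The expected level of compound 4 leans on compound 2 at 70 nM, with a wide margin on either side. For compound 4 the estimated value is 8 nM, with an expected range of 1 nM to 50 nM.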

Compound 4, concentration for 50% growth inhibition: < 10 nM
Compound 4 was reported as a limit; the forecaster's own chance of this, stated with the estimate: 50%; the middle value is on the limit's open side.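

No step from compound 3 to compound 4 can be read, because both results stop at the same limit of the assay rather than giving a number: the limit of < 10 nM in this assay, at which 2 of the 4 values shown sit.

The compounds shown leave open how much methyl in place of fluoro on an aromatic carbon changes the result in this assay, and how compound 3 and compound 4 rank against each other.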